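Adding a methoxy group at the end of the chain

The source may report more compounds than this note shows. Statements on the series, on what has been measured and on what is new or still open speak of the compounds shown alone.

Measured compounds:
- compound 1, `CCOC(=O)c1cn(Cc2nnc(-c3cc(S(N)(=O)=O)c(SCc4ccccc4)cc3Cl)o2)nn1`: 0.085 h
- compound 2, `CC(C)(O)c1cn(Cc2nnc(-c3cc(S(N)(=O)=O)c(SCc4ccccc4)cc3Cl)o2)nn1`: 0.23 h
- compound 3, `NS(=O)(=O)c1cc(-c2nnc(Cn3cc(-c4ccccc4)nn3)o2)c(Cl)cc1SCc1ccccc1`: 0.21 h

All three share a common core and differ only in the group attached to one aromatic carbon. In an ADME assay on microsomes from liver (Homo sapiens) for metabolic stability, read by LC-MS, using NADPH, tested at 5 uM (a higher number here means that the compound lasts longer, a lower number that the compound disappears faster), compound 3 gives 0.21 h, the second highest of the three numbers. Its nearest neighbour is compound 2; the step from a 1.1-fold lower number from compound 2 to compound 3 (0.04 log units; within the scatter) lies within the scatter, so the two cannot be ranked. Compound 1 sits apart: a 2.5-fold higher number from compound 1 to compound 3 (0.39 log units; beyond the scatter) and a 2.7-fold higher number from compound 1 to compound 2 (0.43 log units; beyond the scatter) are both modest but beyond the scatter.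

Compound 4, `COc1ccc(-c2cn(Cc3nnc(-c4cc(S(N)(=O)=O)c(SCc5ccccc5)cc4Cl)o3)nn2)cc1`, keeps the phenyl of compound 3 and differs from it only by methoxy in place of hydrogen on an aromatic carbon. For the measured compounds named here, no measured step touches this exact change. The closest guide is that swapping the whole group, from compound 2 to compound 3, produced no step beyond the scatter, so a smaller alteration on the outer edge of that group is expected to change little. The estimated step of a 1.1-fold lower number from compound 3 to compound 4 (0.02 log units; within the scatter) is therefore expected to stay within the scatter, and compound 4 is estimated at 0.2 h, with a range from 0.1 h to 0.4 h in this assay.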

Compound 4, half-life: 0.215 h
Estimate against measurement, compound 4: 1.1-fold (0.03 log units) below, within the range that was stated.
By their numbers in this assay, from the lowest: compound 1; then compounds 3, 4 and 2 (each within the scatter of the next).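

In this assay, methoxy on the six-membered aromatic ring, para to a large group, gives a number that cannot be told apart from that of the unsubstituted phenyl: a 1.0-fold higher number from compound 3 to compound 4 (0.01 log units; within the scatter) is within the scatter. Compound 4 also cannot be separated from the compound with the 1-hydroxy-1-methylethyl group, as a 1.1-fold lower number from compound 2 to compound 4 (0.03 log units; within the scatter) is within the scatter too, whereas a 2.5-fold higher number from compound 1 to compound 4 (0.40 log units; beyond the scatter) is a modest step beyond it, which leaves the ethoxycarbonyl compound alone at the low end of these four. Nothing available here explains these numbers.

Going by these compounds, a single methoxy at one place is a narrow test, so it remains open whether an amine or a carboxylic acid at that place would stand apart. The same is true of a longer chain in place of methoxy.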